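The compounds below may be only part of what the source reports. "The series", "measured", "known", "first", "only" and "open" are said of these compounds alone.

Series notes, amine substituent on the ring nitrogen of the shared core.

Values in a functional assay on Umbilical vein for antagonist activity at B1 bradykinin receptor (Homo sapiens), using Schild analysis, with a stated time of 30 min; a lower number here means a less potent compound, a higher number a more potent compound, by a factor of ten per unit of this negative logarithm:
compound 1, `COc1cc(C)c(S(=O)(=O)N(C)CCOCC(=O)N2CCN([C@@H]3CN4CCC3CC4)CC2)c(C)c1`, gives 8.1
compound 2, `CCN(CC)CCN1CCN(C(=O)COCCN(C)S(=O)(=O)c2c(C)cc(OC)cc2C)CC1`, gives 7.8
compound 3, `CCN1CCC(N2CCN(C(=O)COCCN(C)S(=O)(=O)c3c(C)cc(OC)cc3C)CC2)CC1`, gives 8.8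

Compound 3 stands highest of the three. The step of a number 0.70 log units higher from compound 1 to compound 3 (beyond the scatter) is beyond the scatter, as is a number 1.00 log units higher from compound 2 to compound 3 (beyond the scatter), so compound 3 is the most potent of the measured set. Between the other two, a number 0.30 log units lower from compound 1 to compound 2 (within the scatter) lies within the scatter, so compound 1 and compound 2 are not separated.

Compound 4, `COc1cc(C)c(S(=O)(=O)N(C)CCOCC(=O)N2CCN(CCN(C)C)CC2)c(C)c1`, is the next member. Relative to compound 3 the change is 2-(dimethylamino)ethyl in place of 1-ethylpiperidin-4-yl on an amine nitrogen in a ring. Within the data shown here, the one measured step that bears on this is a number 1.00 log units higher from compound 2 to compound 3 (beyond the scatter), in which the acyclic 2-(diethylamino)ethyl group gave the lower number and the 1-ethylpiperidin-4-yl group the higher one. Among the measured compounds shown here, compound 4 carries an acyclic 2-(dimethylamino)ethyl group, the same kind of chain as compound 2 but shorter by the count given, and no measured pair separates a dimethylamino chain from a diethylamino chain. A drop of roughly the size seen in the step from compound 2 to compound 3, reversed, is therefore expected, in this assay. Compound 4 is estimated at 7.8, with a range of 7.3 to 8.3. The expected step is a number 1.00 log units lower from compound 3 to compound 4 (beyond the scatter).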

Compound 4, negative logarithm of the antagonist equilibrium constant: 7.4
The estimate for compound 4 lay 0.40 log units above the measured number, and the stated range covers the measured number.
By their numbers in this assay, from the lowest: compound 4; then compounds 2 and 1 (each within the scatter of the next); then compound 3.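

In this assay, among these compounds, the terminal amine of the acyclic chain now counts at this position on the ring nitrogen: a number 0.40 log units lower from compound 2 to compound 4 (beyond the scatter) is the first measured separation of dimethylamino from diethylamino. The two groups carrying rings both stand clear of 2-(dimethylamino)ethyl, in a number 1.40 log units lower from compound 3 to compound 4 (beyond the scatter) and in a number 0.70 log units lower from compound 1 to compound 4 (beyond the scatter) as well, yet a plain split between ring-bearing groups and acyclic chains does not hold, since compound 2 goes against it by staying within the scatter of compound 1. No measurement on hand accounts for these steps.

The compounds shown do not tell whether the high value of compound 3 rests on the piperidine ring itself or on the ethyl group on its nitrogen, and a 1-methylpiperidin-4-yl group or an unsubstituted piperidin-4-yl group would separate the two. Also open, as far as these compounds go, is whether the drop from diethylamino to dimethylamino carries over to a longer chain, such as a 3-(diethylamino)propyl group, or to a terminal amine closed into a pyrrolidine ring.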